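Cytotoxicity limits across the amide series; compound 4 pending

The compounds below may be only part of what the source reports. "The series", "measured", "known", "first", "only" and "open" are said of these compounds alone.

Measured so far in an ADME assay on MDCK cells (Canis lupus familiaris) for cytotoxicity, read by microscopy, with a stated time of 6 days; on this read-out lower numbers stand for higher toxicity in this test and higher numbers for lower toxicity in this test:
- Compound 1 `COc1cccc(N2C(N)=NC(N)=NC23CCN(C(=O)c2ccc(C(F)(F)F)cc2C)CC3)c1`: this assay gives for compound 1 a limit of > 100000 nM.
- Compound 2 `CCCN1C(N)=NC(N)=NC12CCN(C(=O)C1CC1)CC2`: this assay gives for compound 2 a limit of > 100000 nM.
- Compound 3 `CCCN1C(N)=NC(N)=NC12CCN(C(=O)c1c(C)noc1C)CC2`: this assay gives for compound 3 a limit of > 100000 nM.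

Compound 3 stands on a limit, not a number, and the two other values shown are limits as well. Among the measured compounds shown here, the only measured step in this assay, a step that the two limits leave unreadable from compound 2 to compound 3, is left unreadable by the two limits; what the three values share is the limit of > 100000 nM in this assay, at which 3 of the 3 values shown sit.

The unmeasured compound 4 `CCCN1C(N)=NC(N)=NC12CCN(C(=O)NCCC(=O)OCC)CC2` differs from compound 3 in one place:
(2-(ethoxycarbonyl)ethyl)amino in place of 3,5-dimethyl-1,2-oxazol-4-yl on a carbonyl carbon

For the measured compounds named here, no measured step reads on this change, so nothing points in either direction, and the common standing of all three compounds at the limit of > 100000 nM in this assay, at which 3 of the 3 values shown sit, is the only guide. The step from compound 3 to compound 4 is therefore expected to be a number no higher from compound 3 to compound 4 (the limit leaves the size open), none beyond the scatter. Compound 4 is estimated at 100000 nM, with a range from 50000 nM to 100000 nM, most likely again reported as a limit.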

Compound 4, minimum cytotoxic concentration: > 100000 nM
Compound 4 was reported as a limit (the forecaster's own chance of this, stated with the estimate: 85%); the middle value lies on the limit itself.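

In this assay compound 4 gives > 100000 nM, a limit. The steps to compound 4 from compound 2 and from compound 3 cannot be read. The compounds shown leave open whether any group on the carbonyl carbon changes the minimum cytotoxic concentration, since all share one standing: the limit of > 100000 nM in this assay, at which 4 of the 4 values shown sit.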